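A few compounds are considered here, and "the series" means these few. Any claim that something is new, unique, unknown or untested is made for them only; others in the source may bear on it.

In a functional assay on HepG2 cells (Homo sapiens) for antiproliferative activity, read by XTT assay, with a stated time of 72 h (a higher number here means a weaker inhibitor, a lower number a stronger inhibitor), compound 3 (`Cc1nc(N)c2c(-c3ccco3)cn([C@@H]3O[C@H](CO)[C@@H](O)[C@H]3O)c2n1`) gives > 20000 nM, which is a limit and not a number. Compound 2 (`Nc1nc(N)c2c(-c3ccco3)cn([C@@H]3O[C@H](CO)[C@@H](O)[C@H]3O)c2n1`) gives > 20000 nM, which is also a limit. Compound 3 therefore stands at the limit of > 20000 nM in this assay, at which 2 of the 3 values shown sit, and has no measured potency to start from. For the measured compounds named here, compound 1 (`CN(C)c1ncnc2c1c(-c1ccoc1)cn2[C@@H]1O[C@H](CO)[C@@H](O)[C@H]1O`) is the only compound here with a number, at 12500 nM in this assay.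

Compound 4 (`Cc1nc(N)c2c(-c3ccsc3)cn([C@@H]3O[C@H](CO)[C@@H](O)[C@H]3O)c2n1`) is still unmeasured. It carries thiophen-3-yl in place of furan-2-yl on an aromatic carbon, with the rest of compound 3 unchanged.

Going by the values given here, the one measured step is a step that the two limits leave unreadable from compound 2 to compound 3 and it concerns methyl in place of amino, not the group exchanged here, so it gives no size to carry over. Among the compounds with values here, no measured pair covers this exchange. Compound 3 differs from compound 1 in more than one place, so compound 1 at 12500 nM serves only as a rough guide to where a number might fall. No clear gain is expected in this assay, and a second limit is quite possible.

The expected move is an at least 1.1-fold lower number from compound 3 to compound 4 (0.04 log units; that floor lies within the scatter) and this estimate is loose. For compound 4 the estimated value is 18000 nM, with an expected range from 4000 nM to 40000 nM in this assay.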

Compound 4, half-maximal inhibitory concentration: > 20000 nM
Compound 4: a limit, no number; the forecaster's own chance of this, stated with the estimate: 60%; middle value at least 1.1-fold (0.04 log units) away from the limit.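

Compound 4 gives > 20000 nM in this assay, which is a limit and not a number. Compound 3 is also held at a limit, so no step can be read between compound 3 and compound 4, and both stand at: the limit of > 20000 nM in this assay, at which 3 of the 4 values shown sit.

As far as these compounds go, whether thiophen-3-yl in place of furan-2-yl shifts potency on this core remains open.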